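Swapping the aryl group on a sulfonyl sulfur

This account rests on a few compounds, and the source may have more. Where it says the series, first, only, none or still open, it means among the compounds named here.

Among the measured compounds shown here, in an in vitro ADME assay on microsomes from liver (Homo sapiens) for metabolic stability (on this read-out lower numbers stand for slow clearance and higher numbers for fast clearance), compound 1 (`COc1cccc(S(=O)(=O)c2c(C)n(CC(=O)O)c3ccc(C)cc23)c1`) gives 3 mL.min-1.g-1 as the only exact number among the compounds measured so far. Compound 2 (`Cc1ccc2c(c1)c(Sc1ccc(Cl)cc1)c(C)n2CC(=O)O`) gives < 3 mL.min-1.g-1 and this is a limit of the assay, not a number. For the measured compounds named here, the picture is therefore short, with the limit of < 3 mL.min-1.g-1 in this assay, at which 1 of the 2 values shown sits, as the one further reading.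

The unmeasured compound 3 (`Cc1ccc2c(c1)c(S(=O)(=O)c1ccccc1Cl)c(C)n2CC(=O)O`) keeps the core of compound 1 and differs from it in one place, with 2-chlorophenyl in place of 3-methoxyphenyl on a sulfonyl sulfur. Going by the values given here, no measured pair here differs in one place, so the data give no direct size for such a swap. The reading of 3 mL.min-1.g-1 for compound 1 is the only anchor for an expectation. In this assay the expected no change at the digits printed from compound 1 to compound 3 (within the scatter) is estimated to stay within the usual scatter, in neither direction. A reading that is again only a limit would not be a surprise for compound 3. For compound 3 the expected value in this assay is 3 mL.min-1.g-1 with an estimated range of 2 mL.min-1.g-1 to 7 mL.min-1.g-1 around it.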

Compound 3, intrinsic clearance in microsomes: < 1 mL.min-1.g-1
Compound 3 ended at the assay's limit; the forecaster's own chance of this, stated with the estimate: 50%; middle value at least 3.0-fold (0.47 log units) away from the limit.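

Among the compounds shown here, the swap gives the first measured step at this position: with 2-chlorophenyl in place of 3-methoxyphenyl on a sulfonyl sulfur whose other neighbours are aromatic carbon, this assay shows an at least 3.0-fold lower number from compound 1 to compound 3 (0.47 log units; beyond the scatter). Compound 3 gives < 1 mL.min-1.g-1, which is a limit of the assay and not a number. The step therefore fixes a direction and a smallest size, while its full size stays out of reach of the read-out: the limit of < 1 mL.min-1.g-1 in this assay, at which 1 of the 3 values shown sits.

The compounds shown leave open whether the step follows the chlorine or its place on the ring, since 2-chlorophenyl and 3-methoxyphenyl differ in both, and a 3-chlorophenyl or 2-methoxyphenyl group on the same sulfur would part the two. Also open, going by these compounds, is whether an aromatic ring holding nitrogen, such as pyridyl, or a ring carrying an amine, would keep the reading at the limit on this sulfonyl sulfur.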